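A few compounds are considered here, and "the series" means these few. Any claim that something is new, unique, unknown or untested is made for them only; others in the source may bear on it.

In a functional assay, read by spectrophotometry, with a stated time of 30 min (on this read-out higher numbers stand for weaker inhibition and lower numbers for stronger inhibition), compound 1 (`CC(C)(C)c1cc(/C=C/C(=O)NC2CCN(Cc3ccccc3)CC2)cc(C(C)(C)C)c1O`) gives 71900 nM and compound 2 (`CC(C)(C)c1cc(/C=C/C(=O)NCCC2CCN(Cc3cccc(F)c3)CC2)cc(C(C)(C)C)c1O`) gives 55200 nM on the same read-out. The gap between these two values lies within the usual scatter of repeated measurements, so compound 2 stands level with compound 1 and the two cannot be ranked. Going by the values given here, no measured pair yet isolates a single structural change. Compound 3 (`CC(C)(C)c1cc(/C=C/C(=O)NCCC2CCN(Cc3cccc([N+](=O)[O-])c3)CC2)cc(C(C)(C)C)c1O`) differs from compound 2 in one place, with nitro in place of fluoro on an aromatic carbon so that a 3-fluorobenzyl becomes a 3-nitrobenzyl. Among the compounds with values here, no measurement yet shows what this exchange does in this assay and no shift beyond the scatter is expected in either direction. Within the data shown here, that expectation rests only on compound 2, whose 55200 nM remains within the scatter of the one other value available. The expected change is a 1.1-fold lower number from compound 2 to compound 3 (0.04 log units; within the scatter) and it would be too small to read as a real difference. In this assay compound 3 is estimated at 50000 nM with a likely range from 20000 nM to 120000 nM in repeated measurements.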

Compound 3, half-maximal inhibitory concentration: 78100 nM
The estimate for compound 3 lay 1.6-fold (0.19 log units) below the measured number; measured number inside the range.
By their numbers in this assay, from the lowest: compounds 2, 1 and 3 (each within the scatter of the next).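

In this assay, going by these compounds alone, the pair gives the first reading of a single exchange, with nitro in place of fluoro on an aromatic carbon, and the result is a 1.4-fold higher number from compound 2 to compound 3 (0.15 log units; within the scatter). At this place, meta to a large group, the 3-fluorobenzyl and the 3-nitrobenzyl therefore cannot be told apart, even though the entering group brings 3 heavy atoms and 2 hydrogen-bond acceptors where the leaving one has a single fluorine and none. Nothing measured here accounts for this outcome, and the reading rests on one pair only.

As far as these compounds go, it remains open whether this aromatic carbon is insensitive to substitution in general, since an amine, a methoxy group, a carboxylic acid or plain hydrogen at the same place could still shift the number beyond the scatter. Compound 1 and compound 2 differ in more than one place, so the contribution of the chain on the amide nitrogen also remains unresolved, and a longer chain or a shorter one in an otherwise unchanged compound would be needed to isolate it.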